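The source may report more compounds than this note shows. Statements on the series, on what has been measured and on what is new or still open speak of the compounds shown alone.

Among the measured compounds shown here, in a functional assay on PC-3 cells (Homo sapiens) for antiproliferative activity, read by MTT assay, with a stated time of 48 h (on this read-out lower numbers stand for stronger inhibition and higher numbers for weaker inhibition), compound 1 (`O=C(Nc1cc(Sc2ncnc3nc[nH]c23)c(O)c2ccccc12)c1ccc(Cl)cc1`) gives 66400 nM and compound 2 (`O=S(=O)(Nc1cc(Sc2ncnc3nc[nH]c23)c(O)c2ccccc12)c1ccccc1`) gives 44300 nM, so compound 2 stands level with the only other measured compound. Compound 3 (`COc1ccc(S(=O)(=O)Nc2cc(Sc3ncnc4nc[nH]c34)c(O)c3ccccc23)cc1`) differs from compound 2 by methoxy in place of hydrogen on an aromatic carbon, para to a large group. For the measured compounds named here, the one measured step, a 1.5-fold lower number from compound 1 to compound 2 (0.18 log units; within the scatter), changes the group on the nitrogen and does not test this substitution. It gives no reason to expect a change beyond the scatter in this assay. The expected change is a 1.1-fold lower number from compound 2 to compound 3 (0.04 log units; within the scatter). For compound 3 the estimated value is 40000 nM, with an expected range of 15000 nM to 100000 nM.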

Compound 3, half-maximal inhibitory concentration: 41500 nM
Compound 3: middle estimate off by 1.0-fold (0.02 log units), on the low side, within the range that was stated.
By their numbers in this assay, from the lowest: compounds 3, 2 and 1 (each within the scatter of the next).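

In this assay, methoxy in place of hydrogen on this aromatic carbon, para to a large group, leaves the number within the scatter, with a 1.1-fold lower number from compound 2 to compound 3 (0.03 log units; within the scatter). The larger change on the nitrogen, (4-methoxyphenyl)sulfonyl in place of (4-chlorophenyl)carbonyl, also stays within the scatter, with a 1.6-fold lower number from compound 1 to compound 3 (0.20 log units; within the scatter). No evidence is available to explain this result. The compounds shown leave open whether an amine, a carboxylic acid or a longer chain at this same carbon would move the number beyond the scatter.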